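Cyclohexylmethyl in place of 2-fluorobenzyl on the ring amine

The source may report more compounds than this note shows. Statements on the series, on what has been measured and on what is new or still open speak of the compounds shown alone.

Compound 1, `CCCCCCCN1CCC(C(=O)Nc2cc(Cl)c(N)cc2OC)CC1`, gives > 10 mg/kg in a functional assay on the whole organism for antagonist activity, with Mus musculus as the target (a higher number here means that more compound is needed for the effect, a lower number that less compound is needed), a limit of the assay. Compound 2, `COc1cc(N)c(Cl)cc1NC(=O)C1CCN(CC2CC2)CC1`, gives > 10 mg/kg there, also a limit. Compound 3, `COc1cc(N)c(Cl)cc1NC(=O)C1CCN(Cc2ccccc2F)CC1`, gives > 4 mg/kg, again a limit.

Going by the values given here, compound 3 therefore stands only at a limit, and the two other values shown are limits too, so no compound here has a true number. The change to compound 4, `COc1cc(N)c(Cl)cc1NC(=O)C1CCN(CC2CCCCC2)CC1`, is cyclohexyl in place of 2-fluorophenyl on a saturated chain carbon bound to an amine nitrogen in a ring. The measured steps, a step that the two limits leave unreadable from compound 1 to compound 2, a step that the two limits leave unreadable from compound 1 to compound 3 and a step that the two limits leave unreadable from compound 2 to compound 3, all involve the same place and all remain unreadable, because the limit of > 10 mg/kg in this assay, at which 2 of the 3 values shown sit, and the limit of > 4 mg/kg in this assay, at which 1 of the 3 values shown sits, bracket every value. They bear on the present change in kind but give no size and no direction, so no step beyond the scatter can be read from them.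

The expected step that the limit leaves unreadable from compound 3 to compound 4 is estimated to be near zero, with a wide range. Compound 4 is expected to give about 10 mg/kg, estimated between 4 mg/kg and 30 mg/kg, and most likely to be reported again only as a limit.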

Compound 4, dose for half-maximal effect: 2.9 mg/kg
For compound 4 the middle estimate is 3.4-fold (0.54 log units) above the measured one, outside the stated range (below it).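

At this place, on a saturated chain carbon bound to an amine nitrogen in a ring, compound 4 is the only compound shown with a true number rather than a limit in this assay, which gives the series its first firm reading at 2.9 mg/kg. Cyclohexyl clearly outdoes two of the other groups, with an at least 3.4-fold lower number from compound 1 to compound 4 (0.53 log units; beyond the scatter) and an at least 3.4-fold lower number from compound 2 to compound 4 (0.53 log units; beyond the scatter), whereas the change from the aromatic ring to the non-aromatic six-membered ring gives only an at least 1.3-fold lower number from compound 3 to compound 4 (0.13 log units; that floor lies within the scatter). That last floor does not establish a real difference, though a larger step remains possible, because compound 3 has only a limit: the limit of > 4 mg/kg in this assay, at which 1 of the 4 values shown sits.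

On these data alone, the steps among compounds 1, 2 and 3 still cannot be read, because all three stand at limits: the limit of > 10 mg/kg in this assay, at which 2 of the 4 values shown sit. Also open is how far the cyclohexyl result depends on the size of the ring, which cyclopentylmethyl could test, and whether a plain benzyl without the fluorine would read any differently from 2-fluorobenzyl at this place.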